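Amide nitrogen substituent variation in one shared-core series

This account rests on a few compounds, and the source may have more. Where it says the series, first, only, none or still open, it means among the compounds named here.

The series keeps one core and varies the group on the amide-type nitrogen. Compound 1 `COc1ccc2c(=O)c(/C=C/C(=O)NCc3ccccc3)coc2c1` carries a benzyl there; in a functional assay on HeLa cells (Homo sapiens) for inhibition, read by MTT assay, with a stated time of 48 h (a lower number here means a stronger inhibitor, a higher number a weaker inhibitor), compound 1 gives 33400 nM. Compound 2 `COc1ccc2c(=O)c(/C=C/C(=O)NCc3ccc(C)cc3)coc2c1` carries a 4-methylbenzyl. In this assay compound 2 gives > 100000 nM, which is a limit of the assay and not a number (the limit of > 100000 nM in this assay, at which 1 of the 2 values shown sits). The step of an at least 2.9-fold higher number from compound 1 to compound 2 (0.47 log units; beyond the scatter) therefore leaves compound 2 as the weaker of the two measured compounds, with only a limit known for it.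

Compound 3 `COc1ccc(NC(=O)/C=C/c2coc3cc(OC)ccc3c2=O)cc1` is next to be measured in this assay. It differs from compound 2 as follows: 4-methoxyphenyl in place of 4-methylbenzyl on an amide-type nitrogen. Among the measured compounds shown here, the only measured step, an at least 2.9-fold higher number from compound 1 to compound 2 (0.47 log units; beyond the scatter), concerns a methyl in place of hydrogen on an aromatic carbon and points toward weaker inhibition; it does not test the exchange of a 4-methylbenzyl for a 4-methoxyphenyl, so the direction for compound 3 is open. Since compound 2 stands at a limit, compound 3 is expected to remain weak, estimated at 60000 nM with a range of 20000 nM to 150000 nM. This corresponds to an expected step of an at least 1.6-fold lower number from compound 2 to compound 3 (0.22 log units; that floor lies within the scatter), which may again end at a limit.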

Compound 3, half-maximal inhibitory concentration: 13000 nM
Compound 3: middle estimate off by 4.6-fold (0.66 log units), on the high side; the whole stated range lies above it.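

In this assay, 4-methoxyphenyl in place of benzyl on the amide-type nitrogen gives a 2.6-fold lower number from compound 1 to compound 3 (0.41 log units; beyond the scatter), the first step shown in the series toward a lower number. Set against the 4-methylbenzyl group, the same 4-methoxyphenyl gives an at least 7.6-fold lower number from compound 2 to compound 3 (0.88 log units; beyond the scatter), so the group on this nitrogen can move the read-out in either direction, and the weak end seen with compound 2 does not hold for every aromatic group placed there. The size of that larger step is only a floor, since compound 2 stands at a limit of the assay and not at a number: the limit of > 100000 nM in this assay, at which 1 of the 3 values shown sits.

Both steps to compound 3 remove the methylene of the benzyl type and change the ring substituent together, so the compounds shown do not separate these two changes; plain phenyl and 4-methoxybenzyl on the same nitrogen would tell them apart. Also open, going by these compounds, is how a longer chain such as phenethyl, or a ring carrying a basic amine, would read in this assay on this nitrogen with the shared core unchanged.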